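A few compounds are considered here, and "the series" means these few. Any claim that something is new, unique, unknown or untested is made for them only; others in the source may bear on it.

Measured in a functional assay on Jurkat cells (Homo sapiens) for cytotoxicity, with a stated time of 72 h; a lower number here means that less compound is needed, a higher number that more compound is needed for the effect:
- Compound 1 `C=C[C@@](C)(/C=C/c1ccc(O)cc1)CCC1OC1(C)C`: > 49000 nM, a limit
- Compound 2 `C=C[C@@](C)(/C=C/c1ccc(O)cc1)CCC(O)C(C)(C)O`: > 49000 nM, a limit
- Compound 3 `C=C[C@@](C)(/C=C/c1ccc(O)c(/C=C/C(=O)c2ccccc2)c1)CCC=C(C)C`: > 49000 nM, a limit

Compound 3 gives only a limit, > 49000 nM, and no number. The whole series stands the same way: the limit of > 49000 nM in this assay, at which 3 of the 3 values shown sit. Compound 4 `C=C[C@@](C)(/C=C/c1ccc(O)c(/C=C/C(N)=O)c1)CCC=C(C)C` changes benzoyl to carbamoyl, with amino in place of phenyl on a carbonyl carbon. Among the compounds with values here, the only measured step, a step that the two limits leave unreadable from compound 1 to compound 2, involves different groups and has no readable size, so it offers no guide to this change. Within the data shown here, no step of known size or direction is therefore expected in this assay, and the expected step is a number no higher from compound 3 to compound 4 (the limit leaves the size open). Compound 4 is estimated at 49000 nM, with an expected range of 15000 nM to 100000 nM.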

Compound 4, half-maximal effective concentration: > 49000 nM
Compound 4 ended at the assay's limit; the forecaster's own chance of this, stated with the estimate: 70%; the middle value lies on the limit itself.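

No step can be read between compound 3 and compound 4, since each gives only a limit: the limit of > 49000 nM in this assay, at which 4 of the 4 values shown sit.

The compounds shown leave open whether carbamoyl in place of benzoyl changes the concentration needed for the effect in this assay.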